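Trading one chlorine for three on the aryl ether of compound 1

A few compounds are considered here, and "the series" means these few. Any claim that something is new, unique, unknown or untested is made for them only; others in the source may bear on it.

Compound 1 `NC1=NC2(CCSCC2)N(OCCCOc2cccc(Cl)c2)C(N)=N1` — 60 nM
Compound 2 `NC1=NC2(CCOCC2)N(OCCCOc2ccc(Cl)c(Cl)c2)C(N)=N1` — 790 nM
Compound 3 `NC1=NC2(CCOCC2)N(OCCCOc2ccc(Cl)cc2Cl)C(N)=N1` — 70 nM

Of the compounds shown here, three sharing the same core have been tested in a functional assay on A549 cells (Homo sapiens) for antiproliferative activity, read by MTT assay, with a stated time of 72 h; on this read-out higher numbers stand for weaker inhibition and lower numbers for stronger inhibition. Compound 1 gives the lowest number of the three in this assay. Compound 3 sits within the scatter of compound 1, so the two cannot be told apart. Compound 2, which differs from compound 1 both in the ring that carries the sulfur or oxygen and in the chlorine-bearing phenyl, gives a much higher number.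

Compound 4 `NC1=NC2(CCSCC2)N(OCCCOc2cc(Cl)c(Cl)cc2Cl)C(N)=N1` has not yet been measured. It differs from compound 1 in one place: 2,4,5-trichlorophenyl in place of 3-chlorophenyl on an oxygen on a saturated carbon.

Within the data shown here, the only measured single-point step concerns the chlorines on this phenyl: an 11-fold lower number from compound 2 to compound 3 (1.05 log units; beyond the scatter). Among the measured compounds shown here, that step shows that moving chlorines around the ring can change the result by a large amount, but no measured pair matches the present change directly. The 2,4,5-trichlorophenyl that enters carries the chlorines of the 2,4-dichlorophenyl of compound 3, whose number lies close to that of compound 1, together with one more chlorine. A modest step in this assay is therefore expected, in either direction, with wide uncertainty; the expected change is a 2.5-fold higher number from compound 1 to compound 4 (0.40 log units; beyond the scatter).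

For compound 4 the estimated result in this assay is 150 nM, with a likely range from 40 nM to 600 nM.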

Compound 4, half-maximal inhibitory concentration: > 100000 nM
Compound 4 gave a limit, no number; the forecaster's own chance of this, stated with the estimate: 3%; at least 660-fold (2.82 log units) between middle value and limit.
By their numbers in this assay, from the lowest: compounds 1 and 3 (each within the scatter of the next); then compound 2. At a limit, above all of these: compound 4.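

In this assay compound 4 gives > 100000 nM, which is a limit and not a number. Putting 2,4,5-trichlorophenyl in place of 3-chlorophenyl gives an at least 1600-fold higher number from compound 1 to compound 4 (3.22 log units; beyond the scatter), so a single change on this phenyl, held on an oxygen on a saturated carbon, can matter far more than the earlier step on the same phenyl, an 11-fold lower number from compound 2 to compound 3 (1.05 log units; beyond the scatter), had shown. The number and the placement of the chlorines change together in this one step, and of the compounds shown only compound 4 stands at the limit: the limit of > 100000 nM in this assay, at which 1 of the 4 values shown sits.

The compounds shown leave open whether the added chlorines or their new placement drives this step, and a 2,4-dichlorophenyl or a 3,4-dichlorophenyl on the ring that carries the sulfur would begin to separate the two. Also open, going by these compounds, is how far the phenyl can be changed in other ways, for instance with a fluorine or a methoxy group in place of chlorine, or with a longer chain between the shared core and the phenyl.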